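The compounds below may be only part of what the source reports. "The series", "measured", "known", "first", "only" and "open" are said of these compounds alone.

Compound 1 `CCCN(CC[C@H]1CC[C@H](NC(=O)/C=C/c2ccc(F)cc2)CC1)[C@H]1CCc2nc(N)sc2C1` and compound 2 `CCCN(CC[C@H]1CC[C@H](NC(=O)c2cccc3cnccc23)CC1)[C@H]1CCc2nc(N)sc2C1` share one core and differ only in the group on the carbonyl carbon. In an assay on brain for displacement of a labelled ligand from D(3) dopamine receptor (Rattus norvegicus) (a higher number here means a weaker inhibitor, a lower number a stronger inhibitor), compound 1 gives 1 nM, and in this assay compound 2 gives 5.9 nM, the higher of the two numbers; the step of a 5.9-fold higher number from compound 1 to compound 2 (0.77 log units; beyond the scatter) shows that exchanging the group on the carbonyl carbon moves the number modestly. Compound 3 `CCCN(CC[C@H]1CC[C@H](NC(=O)c2cccc(-n3cncn3)c2)CC1)[C@H]1CCc2nc(N)sc2C1` carries another exchange at the same place: 3-(1H-1,2,4-triazol-1-yl)phenyl in place of isoquinolin-5-yl on a carbonyl carbon. For the measured compounds named here, only that one step bears on this change, so a modest step is expected, a 1.4-fold higher number from compound 2 to compound 3 (0.13 log units; within the scatter), and for compound 3 the estimate is 8 nM, between 2 nM and 30 nM.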

Compound 3, inhibition constant: 3 nM
Compound 3: middle estimate off by 2.7-fold (0.43 log units), on the high side; the measured number falls inside the stated range.
By their numbers in this assay, from the lowest: compound 1; then compounds 3 and 2 (each within the scatter of the next).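

In this assay, the change from the fused isoquinolin-5-yl group to 3-(1H-1,2,4-triazol-1-yl)phenyl, which carries more hydrogen-bond acceptors, is tolerated at this position (a 2.0-fold lower number from compound 2 to compound 3 (0.29 log units; within the scatter)). The 2-(4-fluorophenyl)ethenyl group of compound 1 keeps a modest lead (a 3.0-fold higher number from compound 1 to compound 3 (0.48 log units; beyond the scatter)). No supporting data explain these differences.

As far as these compounds go, it remains open how much of that lead comes from the ethenyl chain and how much from the fluorine. Whether a plain phenyl on the carbonyl carbon would match the triazole-bearing group is also unresolved.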